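Trifluorophenyl in place of carbamoylphenyl on the amide nitrogen

The compounds below may be only part of what the source reports. "The series", "measured", "known", "first", "only" and "open" are said of these compounds alone.

Among the measured compounds shown here, compound 1 (`CC(C)n1ncc2c(C(=O)Nc3cccc(C(N)=O)c3)cc(-c3cccs3)nc21`) stands at the low end of the three numbers known in an ADME assay on LLC-MK2 cells (Macaca mulatta) for cytotoxicity, read by spectrophotometry and crystal violet staining, with a stated time of 4 days; on this read-out lower numbers stand for higher toxicity in this test and higher numbers for lower toxicity in this test: compound 1 gives 25000 nM there, level with compound 3 (`CNS(=O)(=O)c1cccc(NC(=O)c2cc(-c3cccs3)nc3c2cnn3C(C)C)c1`) at 25000 nM. Compound 2 (`CC(C)n1ncc2c(C(=O)Nc3ccccc3F)cc(-c3ccccn3)nc21`) gives 100000 nM, a number higher than that of compound 1 by more than the usual scatter. Compound 4 (`CC(C)n1ncc2c(C(=O)Nc3c(F)cc(F)cc3F)cc(-c3cccs3)nc21`) keeps the core of compound 1 and carries 2,4,6-trifluorophenyl in place of 3-carbamoylphenyl on an amide-type nitrogen. For the measured compounds named here, only one measured step bears directly on this group, the exchange of carbamoyl for methylsulfamoyl on an aromatic carbon (no change at the digits printed from compound 1 to compound 3 (within the scatter)), and it stays within the scatter. That step keeps the carbamoyl-bearing ring's replacement close to home, however, and says little about a group without a hydrogen-bond donor. Going by the values given here, compound 2 also has fluorine on the phenyl group at that nitrogen and shows the higher number, yet it differs from compound 1 elsewhere as well, and no measured step isolates the fluorine. A modest move toward a higher number, meaning lower toxicity in this test, is therefore expected, though it may not clear the scatter. The estimated size of the change is a 1.6-fold higher number from compound 1 to compound 4 (0.20 log units; within the scatter) in this direction. Compound 4 is expected at 40000 nM within a range of 16000 nM to 100000 nM in this assay.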

Compound 4, half-maximal cytotoxic concentration: > 200000 nM
Compound 4 was reported as a limit; the forecaster's own chance of this, stated with the estimate: 15%; middle value at least 5.0-fold (0.69 log units) away from the limit.
By their numbers in this assay, from the lowest: compounds 1 and 3 (each within the scatter of the next); then compound 2. At a limit, above all of these: compound 4.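

Putting 2,4,6-trifluorophenyl in place of 3-carbamoylphenyl on the amide-type nitrogen gives an at least 8.0-fold higher number from compound 1 to compound 4 (0.90 log units; beyond the scatter) in this assay. This shows that a change at this position can move the read-out toward lower toxicity in this test by more than the scatter, which the earlier change on the same phenyl group, no change at the digits printed from compound 1 to compound 3 (within the scatter), did not show. Compound 4 gives > 200000 nM, which is a limit of the assay and not a number, so the step has a lower bound but no known upper size: the limit of > 200000 nM in this assay, at which 1 of the 4 values shown sits.

The compounds shown do not separate the loss of carbamoyl from the entry of the three fluorines, and with the rest of compound 1 kept, an unsubstituted phenyl group on the same nitrogen would help to tell these two apart. On these data alone, it also remains open whether a phenyl group bearing a single fluorine, an amine or a carboxylic acid at this nitrogen would stay close to compound 1 or move toward compound 4.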